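The compounds below may be only part of what the source reports. "The series", "measured", "known", "first", "only" and "open" are said of these compounds alone.

Three compounds have so far been measured in an ADME assay on HepG2 cells (Homo sapiens) for cytotoxicity, read by CellTiter-Glo and ATP content, with a stated time of 72 h; on this read-out higher numbers stand for an effect only at larger amounts of compound and lower numbers for an effect already at smaller amounts:

Compound 1 `CN(Cc1ccccc1)C(=O)C1CCN(C(=O)c2ccc(S(C)(=O)=O)c([N+](=O)[O-])c2)CC1`: > 27000 nM
Compound 2 `CN(Cc1ccccc1F)C(=O)C1CCN(C(=O)c2ccc(S(C)(=O)=O)c([N+](=O)[O-])c2)CC1`: > 27000 nM
Compound 3 `CN(Cc1ccccc1)C(=O)CNC(=O)c1ccc(S(C)(=O)=O)c([N+](=O)[O-])c1`: > 27000 nM

Each of these three values is a limit of the assay rather than a number. For compound 1 the value > 27000 nM is such a limit. For compound 2 the value > 27000 nM is likewise a limit. For compound 3 the value > 27000 nM is a limit too. All three therefore sit at the limit of > 27000 nM in this assay, at which 3 of the 3 values shown sit, meaning that no loss of cell viability was seen at any amount of compound tested.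

Compound 2 differs from compound 1 by fluoro in place of hydrogen on an aromatic carbon. The step that the two limits leave unreadable from compound 1 to compound 2 cannot be given a size, since both ends are limits. Compound 4 `CN(Cc1cccc(F)c1)C(=O)CNC(=O)c1ccc(S(C)(=O)=O)c([N+](=O)[O-])c1` has not yet been measured; it differs from compound 3 by fluoro in place of hydrogen on an aromatic carbon. This is the same kind of change as that from compound 1 to compound 2, but not the same: in compound 2 the fluoro sits ortho to a large group, in compound 4 it sits meta to a large group. The difference between the core of compound 1 and the core of compound 3 is not broken down here.

For compound 4 the step that the limit leaves unreadable from compound 3 to compound 4 is expected to be unreadable in the same way, because the limit of > 27000 nM in this assay, at which 3 of the 3 values shown sit, holds every measured value and the same kind of change left compound 2 at that limit. Compound 4 is estimated to fall at 40000 nM, most likely reported again only as a limit, with a range from 14000 nM to 120000 nM.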

Compound 4, half-maximal effective concentration: > 27000 nM
Compound 4 was reported as a limit; the forecaster's own chance of this, stated with the estimate: 85%; the middle value does not contradict the limit.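

Compound 3 and compound 4 are both reported only as limits, so the swap of hydrogen for fluoro between them cannot be given a size and no new step can be read. Every value shown now sits at the same limit: the limit of > 27000 nM in this assay, at which 4 of the 4 values shown sit. The compounds shown leave open at what amount any of them would lower cell viability, and whether fluoro or the core changes that amount.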